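This account rests on a few compounds, and the source may have more. Where it says the series, first, only, none or still open, it means among the compounds named here.

Compound 3 `CN(C)C(=O)c1cc2cnc(Nc3ccc(NC(=O)C4(C(=O)Nc5cccc(Cl)c5)CC4)cc3)nc2n1C1CCCC1` gives the highest of the three numbers in a functional assay on NCI-H460 cells (Homo sapiens) for inhibition, read by CCK-8 assay, with a stated time of 72 h, tested at 10 uM (on this read-out higher numbers stand for more inhibition of growth at the one concentration tested and lower numbers for less inhibition of growth), at 101%. Its two neighbours sit close by: compound 2 `CN(C)C(=O)c1cc2cnc(Nc3ccc(NC(=O)C4(C(=O)Nc5ccc(Br)cc5)CC4)cc3)nc2n1C1CCCC1` gives 96.4% and compound 1 `CN(C)C(=O)c1cc2cnc(Nc3ccc(NC(=O)C4(C(=O)Nc5cccc(O)c5)CC4)cc3)nc2n1C1CCCC1` gives 94.9%, and both steps up to compound 3, a number 4.6 percentage points higher from compound 2 to compound 3 (within the scatter) and a number 6.1 percentage points higher from compound 1 to compound 3 (within the scatter), stay within the scatter, as does a number 1.5 percentage points higher from compound 1 to compound 2 (within the scatter). The move to compound 4 `CN(C)C(=O)c1cc2cnc(Nc3ccc(NC(=O)C4(C(=O)Nc5ccc(O)cc5)CC4)cc3)nc2n1C1CCCC1` is 4-hydroxyphenyl in place of 3-chlorophenyl on an amide-type nitrogen. The step that bears on it most directly is a number 6.1 percentage points higher from compound 1 to compound 3 (within the scatter), where hydroxy stood against chloro on the ring and the numbers did not separate beyond the scatter; the steps of a number 1.5 percentage points higher from compound 1 to compound 2 (within the scatter) and a number 4.6 percentage points higher from compound 2 to compound 3 (within the scatter) show the same picture for a change of ring substituent on that amide-type nitrogen. For the measured compounds named here, no measured step tells the 4-hydroxyphenyl from the 3-hydroxyphenyl of compound 1. Compound 4 is therefore expected to show no step beyond the scatter in this assay, a number 5 percentage points lower from compound 3 to compound 4 (within the scatter). The estimate for compound 4 is 96%, with a range from 86% to 102%.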

Compound 4, percent growth inhibition at one concentration: 104%
Estimate against measurement, compound 4: 8 percentage points below; the whole stated range lies below it.
By their numbers in this assay, from the lowest: compounds 1, 2, 3 and 4 (each within the scatter of the next).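

In this assay the 4-hydroxyphenyl on the amide-type nitrogen does not separate from any of the other three rings: a number 3 percentage points higher from compound 3 to compound 4 (within the scatter), a number 7.6 percentage points higher from compound 2 to compound 4 (within the scatter) and a number 9.1 percentage points higher from compound 1 to compound 4 (within the scatter). For the compounds shown here, the last of these is the first direct comparison of the two hydroxyphenyl groups, and it shows that the hydroxy can stand in either of these two ring placings without the number moving beyond the scatter. The evidence at hand offers no explanation for this flat picture.

As far as these compounds go, because all four compounds were read at one concentration, it remains open whether they would separate at lower concentrations. From the compounds shown here alone, it is also open whether this position would hold up with a ring carrying an amine or a carboxylic acid, or with a saturated cyclohexyl ring in place of the phenyl.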